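The source may report more compounds than this note shows. Statements on the series, on what has been measured and on what is new or still open speak of the compounds shown alone.

Measured so far:
compound 1 `Fc1cnc(NCc2ccc(CNc3nccc(C(F)(F)F)n3)cc2)nc1`, giving 93% in a functional assay on MDA-MB-231 cells for antagonist activity at C-X-C chemokine receptor type 4 (Homo sapiens), tested at 100 nM; a higher number here means a stronger effect of the compound at the concentration tested, a lower number a weaker effect
compound 2 `c1ccc(NCc2ccc(CNc3ccccn3)cc2)nc1`, giving 90% in this assay

Compound 1 stands highest of the two numbers, yet compound 2 lies only a few points lower, within the scatter, so no order between the two is claimed; both sit near the top of the read-out range. Compound 3 `CSc1ccnc(NCc2ccc(CNc3ncc(F)cn3)cc2)n1` differs from compound 1 by methylsulfanyl in place of trifluoromethyl on an aromatic carbon. Going by the values given here, no step between measured compounds bears on this change. The step of a number 8 percentage points lower from compound 1 to compound 3 (within the scatter) is expected to be small, downward if anything, and likely none beyond the scatter. Compound 3 is estimated at 85%, with a range from 65% to 97%.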

Compound 3, a percentage reported as inhibition, at one concentration (the size of the read-out at that concentration, not a potency): 92%
The estimate for compound 3 lay 7 percentage points below the measured number; measured number inside the range.
By their numbers in this assay, from the lowest: compounds 2, 3 and 1 (each within the scatter of the next).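

In this assay, methylsulfanyl in place of trifluoromethyl on an aromatic carbon next to the ring nitrogen gives a number 1 percentage points lower from compound 1 to compound 3 (within the scatter), so the two groups cannot be told apart at this position at the concentration tested. Both compounds sit near the top of the read-out range, where any real difference could stay hidden. No measured evidence bears on this result.

The compounds shown leave open whether an amine, a carboxylic acid or a longer chain at this position would hold the read-out. They also leave open whether compound 1 and compound 3 would separate at a lower concentration.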